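The compounds below may be only part of what the source reports. "The series", "measured", "known", "first", "only" and "open" are said of these compounds alone.

The measured compounds in an assay on isolated protein for inhibition of complement C1r subcomponent (Homo sapiens), with a stated time of 60 min (on this read-out higher numbers stand for weaker inhibition and lower numbers for stronger inhibition), are these:

compound 1, `O=c1oc(Nc2ccccc2I)nc2ccccc12`: 14700 nM
compound 2, `O=c1oc(Nc2ccccc2I)nc2cc(Cl)ccc12`: 900 nM
compound 3, `O=c1oc(Nc2ccccc2I)nc2cc(Cl)c(Cl)cc12`: > 62500 nM

Compound 2 gives the lowest of the two numbers in this assay. Its nearest neighbour is compound 1, and the change from one to the other is a 16-fold lower number from compound 1 to compound 2 (1.21 log units; beyond the scatter), a chloro entering on an aromatic carbon of the shared core. For compound 3 the assay reports only a limit, (the limit of > 62500 nM in this assay, at which 1 of the 3 values shown sits), and no number. The further chloro thus produces an at least 69-fold higher number from compound 2 to compound 3 (1.84 log units; beyond the scatter).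

Compound 4, `Cc1ccc2c(=O)oc(Nc3ccccc3I)nc2c1`, differs from compound 2 in one place: methyl in place of chloro on an aromatic carbon. Among the compounds with values here, two measured steps bear on this. The gain with chloro in compound 2 was large, and the loss with a second chloro in compound 3 was even larger, so this position of the core is sensitive to substitution. A methyl in the same place keeps a substituent there but not the chloro itself, so some of the gain seen in compound 2 is expected to be given back, with a moderate step beyond the scatter toward a higher number. The expected step from compound 2 to compound 4 is a 2.8-fold higher number from compound 2 to compound 4 (0.44 log units; beyond the scatter). Compound 4 is therefore estimated at 2500 nM, within 800 nM to 8000 nM.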

Compound 4, half-maximal inhibitory concentration: 1500 nM
Compound 4: middle estimate off by 1.7-fold (0.22 log units), on the high side, and the stated range covers the measured number.
By their numbers in this assay, from the lowest: compounds 2 and 4 (each within the scatter of the next); then compound 1. At a limit, above all of these: compound 3.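

In this assay, methyl in place of chloro on this aromatic carbon gives a 1.7-fold higher number from compound 2 to compound 4 (0.22 log units; within the scatter), so the assay does not separate the two groups here, and the earlier gain from compound 1 to compound 2 proves not to depend on chloro itself. Measured from the unsubstituted core, methyl in place of hydrogen gives a 9.8-fold lower number from compound 1 to compound 4 (0.99 log units; beyond the scatter), which makes methyl a second group at this place that ends well apart from the hydrogen of compound 1, whereas the earlier compounds had shown this for chloro alone. Nothing shown here gives a reason why these two different groups end up so alike.

Going by these compounds, it remains open whether a group with other atoms or of greater length on this carbon, such as an amine, a carboxylic acid or a longer chain like propyl, would stay with compound 2 and compound 4 or fall back toward compound 1. Compound 3 stands at a limit, > 62500 nM, and it leaves open whether methyl in place of either of its chloro groups would give a number that can be read in this assay.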